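Hydroxymethyl Replaced by tert-Butyl on the Amide Carbonyl

The source may report more compounds than this note shows. Statements on the series, on what has been measured and on what is new or still open speak of the compounds shown alone.

In a functional assay on HT-29 cells (Homo sapiens) for antiproliferative activity, read by MTT assay, with a stated time of 72 h, tested at 10 uM (a lower number here means less inhibition, a higher number more inhibition at the concentration tested (going by the name of the read-out)), compound 1 `CC(C)C(=O)Nc1cc(Oc2ccc(Nc3nccc4[nH]cc(-c5ccc(F)cc5)c(=O)c34)cc2F)ccn1` gives 83.4%, whereas compound 2 `O=C(CO)Nc1cc(Oc2ccc(Nc3nccc4[nH]cc(-c5ccc(F)cc5)c(=O)c34)cc2F)ccn1` gives 18.5%, the lower of the two numbers. Compound 3 `CC(C)(C)C(=O)Nc1cc(Oc2ccc(Nc3nccc4[nH]cc(-c5ccc(F)cc5)c(=O)c34)cc2F)ccn1` has not been measured; it differs from compound 2 by tert-butyl in place of hydroxymethyl on a carbonyl carbon. For the measured compounds named here, the one step that bears on this change is a number 64.9 percentage points lower from compound 1 to compound 2 (beyond the scatter), and the new change runs in the opposite sense, away from hydroxymethyl toward a group resembling the isopropyl of compound 1. A large rise is therefore expected, a number 59.5 percentage points higher from compound 2 to compound 3 (beyond the scatter). Compound 3 is estimated at 78%, within a range from 55% to 92%.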

Compound 3, a percentage reported as inhibition, at one concentration (the size of the read-out at that concentration, not a potency): -45.8%
Compound 3: middle estimate off by 123.8 percentage points, on the high side; measured number outside the range, below it.
By their numbers in this assay, from the lowest: compound 3; then compound 2; then compound 1.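

At this carbonyl carbon, the tert-butyl group does not restore the number lost with hydroxymethyl: in this assay there is a number 64.3 percentage points lower from compound 2 to compound 3 (beyond the scatter), so hydroxymethyl no longer marks the low end of the series. One added methyl on the isopropyl carbon alone gives a number 129.2 percentage points lower from compound 1 to compound 3 (beyond the scatter), a larger step than the one separating isopropyl from hydroxymethyl. No evidence is available to explain either drop. The compounds shown leave open how an ethyl, a cyclopropyl or an aminomethyl group on this carbonyl carbon would read.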